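The source may report more compounds than this note shows. Statements on the series, on what has been measured and on what is new or still open speak of the compounds shown alone.

Compound 1 `O=C1O/C(=C\Cn2cc(I)c(=O)[nH]c2=O)C(OCc2ccccc2)=C1OCc1ccccc1` gives 5000 nM in a functional assay on HEL cells (Homo sapiens) for cytotoxicity, read by microscopy; on this read-out lower numbers stand for stronger inhibition and higher numbers for weaker inhibition. Compound 2 `O=C1O/C(=C\Cn2cc(Cl)c(=O)[nH]c2=O)C(OCc2ccccc2)=C1OCc1ccccc1` gives 5000 nM in this assay, and the step of no change at the digits printed from compound 1 to compound 2 (within the scatter) shows that this halogen swap left the read-out where it was, so compound 1 stands level with compound 2. Compound 3 `O=C1O/C(=C\Cn2cc(Br)c(=O)[nH]c2=O)C(OCc2ccccc2)=C1OCc1ccccc1` carries bromo in place of iodo on an aromatic carbon, another swap of one halogen for another at the same carbon. For the measured compounds named here, the only comparable step, chloro in place of iodo, was flat, so no shift beyond the scatter is expected, and the step of no change at the digits printed from compound 1 to compound 3 (within the scatter) is estimated to be flat. For compound 3 the expected value is 5000 nM, with a range from 2500 nM to 10000 nM.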

Compound 3, half-maximal inhibitory concentration: 5000 nM
For compound 3 middle estimate and measured number coincide at the digits printed; the measured number falls inside the stated range.
By their numbers in this assay, from the lowest: compounds 1, 2 and 3 (each within the scatter of the next).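

With bromo in place of iodo there is no change at the digits printed from compound 1 to compound 3 (within the scatter), and with bromo in place of chloro there is no change at the digits printed from compound 2 to compound 3 (within the scatter). In this assay, the three halogens shown on this aromatic carbon therefore read alike, which the single chloro for iodo step could not show. No available evidence explains this flat result. The compounds shown leave open whether a group other than a halogen on this carbon, such as an amine, a methyl group or a carboxylic acid, would shift the value.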